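The source may hold more compounds than are shown below. What is called first, only, known or untested is meant among the compounds shown, and "the series" means these compounds.

Measured compounds:
compound 1 `CCC(=O)Oc1ccc2ccc(=O)oc2c1Cc1c(-c2ccccc2)[nH]c2ccccc12` — in an ADME assay on MT4 cells (Homo sapiens) for cytotoxicity, read by MTT assay, with a stated time of 96 h (on this read-out lower numbers stand for higher toxicity in this test and higher numbers for lower toxicity in this test), compound 1 gives a limit of the assay, > 100000 nM
compound 2 `CC(=O)Oc1ccc2c(C)cc(=O)oc2c1Cc1c(-c2ccccc2)[nH]c2ccccc12` — in this assay compound 2 gives a limit of the assay, > 100000 nM
compound 3 `CCC(=O)Oc1ccc2ccc(=O)oc2c1Cc1c[nH]c2ccccc12` — in this assay compound 3 gives 65000 nM

Among the measured compounds shown here, two of the three values sit at the same limit, (the limit of > 100000 nM in this assay, at which 2 of the 3 values shown sit), so only the pair compound 1 to compound 3 yields a measured step. That step, (hydrogen in place of phenyl on an aromatic carbon), gives an at least 1.5-fold lower number from compound 1 to compound 3 (0.18 log units; that floor lies within the scatter). Its floor lies within the usual scatter, and the true size cannot be fixed from a limit; the change is therefore read as no more than a modest move toward a lower number.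

Compound 2 and compound 1 share the same atoms joined differently; the difference between the two cores is not broken down here.

Compound 4 `CC(=O)Oc1ccc2c(C)cc(=O)oc2c1Cc1c[nH]c2ccccc12` stands to compound 2 as compound 3 stands to compound 1: the change is hydrogen in place of phenyl on an aromatic carbon, with the place described in the same words for both pairs, so it is the same kind of change. For the measured compounds named here, for compound 4 a step of about an at least 1.4-fold lower number from compound 2 to compound 4 (0.15 log units; that floor lies within the scatter) is expected, resting on the single measured instance from compound 1 to compound 3, an at least 1.5-fold lower number from compound 1 to compound 3 (0.18 log units; that floor lies within the scatter), and on the fact that compound 2 itself stands at the assay limit. Compound 4 is accordingly estimated at 70000 nM, with a range from 30000 nM to 120000 nM, and a sizable chance that this assay again reports only a limit.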

Compound 4, half-maximal cytotoxic concentration: 100000 nM
Compound 4: middle estimate off by 1.4-fold (0.15 log units), on the low side; the range from low to high includes it.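

Set side by side in this assay, the two cases of hydrogen in place of phenyl on an aromatic carbon read as follows: the same change on two cores in this assay, an at least 1.5-fold lower number (0.18 log units; that floor lies within the scatter) from compound 1 to compound 3 and a number no higher (the limit leaves the size open) from compound 2 to compound 4; the limit leaves it open whether they differ

In this assay compound 2 gives > 100000 nM, which is a limit of the assay, and that limit recurs in the series: the limit of > 100000 nM in this assay, at which 2 of the 4 values shown sit.

Among the compounds shown here, the size of the step on this second core (a number no higher from compound 2 to compound 4 (the limit leaves the size open)) therefore cannot be read, so the pair shows only that the number does not rise on this core; it does not show that the change carries over with the same size, or with any measurable size, from one core to the other.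

At this place on the ring next to the ring nitrogen, the compounds shown carry only phenyl or hydrogen, so it stays open how an amine, a carboxylic acid or a longer chain there would read in this assay. As far as these compounds go, it also stays open whether any such group would give a value well clear of the limit, which is what a size comparison between the two cores would need.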